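Swapping the Amide Aryl Group and the Tolerated Concentration

A few compounds are considered here, and "the series" means these few. Any claim that something is new, unique, unknown or untested is made for them only; others in the source may bear on it.

Three compounds sharing one core have been measured:
- compound 1, `O=C(CSc1snnc1-c1ccc(Br)cc1Br)Nc1ccccn1`, in an ADME assay on MT4 cells (Homo sapiens) for cytotoxicity, read by MTT assay, with a stated time of 5 days (a higher number here means that more compound is tolerated, a lower number that less compound is tolerated), gives 42400 nM.
- compound 2, `O=C(CSc1snnc1-c1ccc(Br)cc1Br)Nc1ccccc1[N+](=O)[O-]`, gives only a limit of the assay, > 235000 nM.
- compound 3, `O=C(CSc1snnc1-c1ccc(Br)cc1Br)Nc1cccnc1Cl`, likewise gives only a limit, > 240000 nM.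

Compound 3 thus stands at the top of what the assay can report, at the limit of > 240000 nM in this assay, at which 1 of the 3 values shown sits. The step that the two limits leave unreadable from compound 2 to compound 3 cannot be read. Compound 4, `O=C(CSc1snnc1-c1ccc(Br)cc1Br)Nc1ccccc1`, differs from compound 3 by phenyl in place of 2-chloropyridin-3-yl on an amide-type nitrogen. For the measured compounds named here, no measured step involves phenyl, so the evidence is indirect: an at least 5.6-fold higher number from compound 1 to compound 3 (0.75 log units; beyond the scatter) and an at least 5.5-fold higher number from compound 1 to compound 2 (0.74 log units; beyond the scatter) show that changing the ring on the amide nitrogen can move the number at least modestly. The step of an at least 2.4-fold lower number from compound 3 to compound 4 (0.38 log units; beyond the scatter) is therefore expected to be a decrease. The estimate for compound 4 is 100000 nM, with a range from 30000 nM to 250000 nM.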

Compound 4, half-maximal cytotoxic concentration: 24800 nM
For compound 4 the middle estimate is 4.0-fold (0.61 log units) above the measured one; the measured number lies below the stated range.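

Taking away the nitro group alone, with hydrogen in its place, gives an at least 9.4-fold lower number from compound 2 to compound 4 (0.97 log units; beyond the scatter), so a single group on this ring can move the number well beyond the scatter. Phenyl in place of 2-chloropyridin-3-yl likewise gives an at least 9.6-fold lower number from compound 3 to compound 4 (0.98 log units; beyond the scatter). Phenyl and pyridin-2-yl, by contrast, cannot be told apart, with a 1.7-fold lower number from compound 1 to compound 4 (0.23 log units; within the scatter).

Going by these compounds, it stays open whether the chlorine or the ring nitrogen of 2-chloropyridin-3-yl accounts for that step. On these data alone, it also stays open whether an amine or a carboxylic acid in place of the nitro group would give a number like that of compound 4.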